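A few compounds are considered here, and "the series" means these few. Any claim that something is new, unique, unknown or untested is made for them only; others in the source may bear on it.

Measured compounds:
Compound 1 `COc1cc2c(Oc3ccc(NC(=O)c4cn(-c5ccccc5Cl)nn4)cc3F)ccnc2cc1OCCCN1CCC(C)CC1` gives 240 nM in a functional assay on MKN-45 cells (Homo sapiens) for cytotoxicity, read by MTT assay, with a stated time of 72 h; a lower number here means a stronger inhibitor, a higher number a weaker inhibitor.
Compound 2 `COc1cc2c(Oc3ccc(NC(=O)c4cn(-c5ccccc5F)nn4)cc3F)ccnc2cc1OCCCN1CCC(C)CC1` gives 130 nM in this assay.
Compound 3 `COc1cc2c(Oc3ccc(NC(=O)c4cn(-c5c(C)cccc5C)nn4)cc3F)ccnc2cc1OCCCN1CCC(C)CC1` gives 4310 nM in this assay.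

Compound 3 stands with the highest number of the three, beyond the scatter from both compound 1 and compound 2. The next compound is compound 4 `COc1cc2c(Oc3ccc(NC(=O)c4cn(-c5ccc(F)c(F)c5)nn4)cc3F)ccnc2cc1OCCCN1CCC(C)CC1`, which carries 3,4-difluorophenyl in place of 2,6-dimethylphenyl on an aromatic nitrogen. The measured steps that bear on this are the two that brought in the 2,6-dimethylphenyl: an 18-fold higher number from compound 1 to compound 3 (1.25 log units; beyond the scatter) and a 33-fold higher number from compound 2 to compound 3 (1.52 log units; beyond the scatter), both large. Compound 4 returns to a fluorinated phenyl, though as 3,4-difluorophenyl rather than the 2-chlorophenyl of compound 1 or the 2-fluorophenyl of compound 2, so a full match with those two is not assured. A large drop in the number is expected, roughly reversing those steps, a 20-fold lower number from compound 3 to compound 4 (1.29 log units; beyond the scatter). Compound 4 is therefore estimated at 220 nM, within 60 nM to 900 nM.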

Compound 4, half-maximal inhibitory concentration: 1290 nM
For compound 4 the middle estimate is 5.9-fold (0.77 log units) below the measured one; measured number above the stated range.
By their numbers in this assay, from the lowest: compounds 2 and 1 (each within the scatter of the next); then compound 4; then compound 3.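

In this assay, 3,4-difluorophenyl recovers only part of what 2,6-dimethylphenyl loses on the aromatic nitrogen, with a 3.3-fold lower number from compound 3 to compound 4 (0.52 log units; beyond the scatter). It still falls short of the two singly halogenated phenyls, with a 9.9-fold higher number from compound 2 to compound 4 (1.00 log units; beyond the scatter) and a 5.4-fold higher number from compound 1 to compound 4 (0.73 log units; beyond the scatter), so fluorine on this phenyl is not enough by itself to reach their level. No measurement on hand accounts for these gaps.

Compound 2 and compound 4 differ in both the number and the placing of fluorine, and these two changes cannot be separated here. As far as these compounds go, whether an unsubstituted phenyl, a methoxyphenyl or an aminophenyl would sit nearer 2-fluorophenyl or 3,4-difluorophenyl remains open.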